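The compounds below may be only part of what the source reports. "The series", "measured", "known", "first", "only" and "open" are said of these compounds alone.

Compound 1 `O=C(/C=C1\CCc2ccc(F)cc21)N1CCCC1` was tested in a functional assay on the whole organism with Rattus norvegicus as the target, at a dose of 20 mg/kg by the oral route (a higher number here means more inhibition at the dose given (going by the name of the read-out), a lower number less inhibition), and gives 10%. Compound 2 `COc1ccc2c(c1)CC/C2=C\C(N)=O` gives 18% in this assay; the two values sit within the usual scatter of each other, so compound 1 is not set apart from its only companion. Compound 3 `CCCNC(=O)/C=C1\CCc2ccc(F)cc21` has not yet been measured. It differs from compound 1 by propylamino in place of pyrrolidin-1-yl on a carbonyl carbon. Within the data shown here, no measured pair shows what this change does, so the step from compound 1 to compound 3 in this assay is expected to stay within the scatter, with no clear direction. Compound 3 is therefore expected to give 12% in this assay, between 0% and 30%, an expected step of a number 2 percentage points higher from compound 1 to compound 3 (within the scatter).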

Compound 3, a percentage reported as inhibition, in the whole organism at one dose (the size of the read-out at that dose, not a potency): 0%
Compound 3: the middle estimate sits 12 percentage points above what was measured; the range from low to high includes it.
By their numbers in this assay, from the lowest: compounds 3, 1 and 2 (each within the scatter of the next, the first and the last beyond it).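

In this assay, among these compounds, the step at this carbonyl carbon, a number 10 percentage points lower from compound 1 to compound 3 (within the scatter), is the first measured for any change at this position. Replacing pyrrolidin-1-yl with propylamino removes the ring and brings in the amide hydrogen, yet the step does not separate the two compounds at this dose. No evidence at hand bears on this result. Going by these compounds, whether piperidin-1-yl, morpholin-4-yl or benzylamino on this carbonyl carbon would move the number beyond the scatter remains open. So does whether the unsubstituted amide would do so on the core of compound 1.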